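This account rests on a few compounds, and the source may have more. Where it says the series, first, only, none or still open, it means among the compounds named here.

In a functional assay on HCT-116 cells (Homo sapiens) for inhibition, read by sulforhodamine B assay, with a stated time of 48 h (on this read-out higher numbers stand for weaker inhibition of growth and lower numbers for stronger inhibition of growth), compound 1 `O=C(Cc1csc2nc(-c3ccc(Br)cc3)cn12)N/N=C/c1ccccc1` gives 9330 nM, while compound 2 `COc1cccc(OC)c1/C=N/NC(=O)Cc1csc2nc(-c3ccc(Br)cc3)cn12` gives 4570 nM, the lower of the two numbers. Compound 3 `O=C(Cc1csc2nc(-c3ccc(Br)cc3)cn12)N/N=C/c1ccc(Cl)cc1Cl` carries 2,4-dichlorophenyl in place of 2,6-dimethoxyphenyl on a carbon with a double bond to nitrogen. Among the measured compounds shown here, the only measured step at this place is modest: a 2.0-fold lower number from compound 1 to compound 2 (0.31 log units; beyond the scatter). With that single step as a guide, no change beyond the scatter is expected in this assay, and the expected result is a 1.2-fold higher number from compound 2 to compound 3 (0.08 log units; within the scatter). For compound 3 the estimated value is 5500 nM, within an expected range of 2200 nM to 14000 nM.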

Compound 3, concentration for 50% growth inhibition: 17000 nM
For compound 3 the middle estimate is 3.1-fold (0.49 log units) below the measured one; measured number outside the range, above it.
By their numbers in this assay, from the lowest: compound 2; then compounds 1 and 3 (each within the scatter of the next).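

Replacing 2,6-dimethoxyphenyl with 2,4-dichlorophenyl on this carbon gives a 3.7-fold higher number from compound 2 to compound 3 (0.57 log units; beyond the scatter) in this assay and so loses the gain seen with compound 2. Measured against plain phenyl, the same group gives a 1.8-fold higher number from compound 1 to compound 3 (0.26 log units; within the scatter) and so adds nothing that stands clear of the scatter, which leaves compound 2 alone apart from the other two. Nothing measured here explains this difference between the two substituted rings. Going by these compounds, it remains open whether a single methoxy group would match compound 2, and how an amine or a carboxylic acid on this ring would behave.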